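Fluoro for chloro, a small step measured twice

The source may hold more compounds than are shown below. What is called first, only, known or untested is meant among the compounds shown, and "the series" means these compounds.

Of the compounds shown here, three have been measured in a functional assay on the whole organism (artery, strain albino) with Rattus norvegicus as the target, with a stated time of 30 min, at a dose of 10 mg/kg by the oral route; a lower number here means less inhibition, a higher number more inhibition at the dose given (going by the name of the read-out).

Compound 1, `COc1ccc(C2N=C(SCc3ccc(Cl)cc3)NC(C)=C2C(=O)Nc2ccc(F)cc2)cc1OC`, gives 5.7%.
Compound 2, `COc1ccc(C2N=C(SCc3ccc(F)cc3)NC(C)=C2C(=O)Nc2ccc(F)cc2)cc1OC`, gives 6.7%.
Compound 3, `CC1=C(C(=O)Nc2ccc([N+](=O)[O-])cc2)C(c2ccc(Br)cc2)N=C(SCc2ccc(Cl)cc2)N1`, gives 6.2%.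

Compound 1 and compound 2 share one core and differ only by fluoro in place of chloro on an aromatic carbon. In this assay this change gave a number 1 percentage points higher from compound 1 to compound 2 (within the scatter), a step that stays within the usual scatter of the measurement. Compound 3 carries a different core; how the two cores differ is not broken down here, and its value lies within the scatter of both compound 1 and compound 2.

Compound 4, `CC1=C(C(=O)Nc2ccc([N+](=O)[O-])cc2)C(c2ccc(Br)cc2)N=C(SCc2ccc(F)cc2)N1`, is related to compound 3 by fluoro in place of chloro on an aromatic carbon, the same change at the same kind of place as that from compound 1 to compound 2. The expected step in this assay is a number 0.8 percentage points higher from compound 3 to compound 4 (within the scatter), small because a number 1 percentage points higher from compound 1 to compound 2 (within the scatter) was small on the other core. Compound 4 is therefore expected to give about 7%, estimated between 0% and 15%.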

Compound 4, a percentage reported as inhibition, in the whole organism at one dose (the size of the read-out at that dose, not a potency): 5.2%
The estimate for compound 4 lay 1.8 percentage points above the measured number; the measured number falls inside the stated range.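

In this assay, fluoro in place of chloro on the core of compound 3 gave a number 1 percentage points lower from compound 3 to compound 4 (within the scatter) and so, like the earlier step, did not stand out from the noise of the measurement. Set side by side, the two steps do not differ, and as far as this read-out can tell, the change carries from one core to the other without a detectable difference: the same change on two cores in this assay, a number 1 percentage points higher (within the scatter) from compound 1 to compound 2 and a number 1 percentage points lower (within the scatter) from compound 3 to compound 4, 2 percentage points apart, within the scatter of two such steps. Among the compounds shown here, this shows only that neither core gave a step that could be resolved at this single oral dose; it does not give the change a direction, and it does not show that the two cores would respond alike to a change with a larger step.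

The compounds shown leave open what a group other than a halogen, such as an amine or a carboxylic acid, would do in place of the chloro or fluoro of the 4-chlorobenzyl or 4-fluorobenzyl group. They also leave open how each of the other parts of the two cores acts on its own in this assay.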